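Removing the sulfonyl group from compound 2

A few compounds are considered here, and "the series" means these few. Any claim that something is new, unique, unknown or untested is made for them only; others in the source may bear on it.

Two compounds of this series have a number in an assay on isolated protein for agonist activity at Alpha-1A adrenergic receptor (Oryctolagus cuniculus); a lower number here means that less compound is needed, a higher number that more compound is needed for the effect. Compound 1, `CS(=O)(=O)Nc1c(O)ccc2c1CCCC2c1c[nH]cn1`, gives 17 nM in this assay. Compound 2, `CC(C)S(=O)(=O)Nc1cccc2c1CCCC2c1c[nH]cn1`, gives 6760 nM in this assay, the highest of the two numbers on hand; compound 1 stands well below it, and the two differ in more than one place, so the gap between them cannot be tied to a single change. Compound 3, `Nc1cccc2c1CCCC2c1c[nH]cn1`, is not yet measured in this assay. It differs from compound 2 by hydrogen in place of isopropylsulfonyl on a nitrogen on an aromatic ring. Among the measured compounds shown here, no step between measured compounds tells how this assay answers to such a change. The step from compound 2 to compound 3 is expected to be small and of uncertain direction, a 1.7-fold lower number from compound 2 to compound 3 (0.23 log units; within the scatter), likely within the scatter. Compound 3 is estimated at 4000 nM, within a range from 700 nM to 25000 nM.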

Compound 3, half-maximal effective concentration: 275 nM
Estimate against measurement, compound 3: 15-fold (1.16 log units) above, and the stated range ends above it.
By their numbers in this assay, from the lowest: compound 1; then compound 3; then compound 2.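

In this assay, hydrogen in place of isopropylsulfonyl on a nitrogen on an aromatic ring gives a 25-fold lower number from compound 2 to compound 3 (1.39 log units; beyond the scatter), so the isopropylsulfonyl group in compound 2 is clearly unfavourable for this read-out compared with no substituent at all. Among the compounds shown here, this is the first step that changes one place only, and it shows that this assay answers strongly to what this nitrogen carries, which the earlier gap between compounds differing in more than one place could not show. Nothing at hand bears on why the number moves this way.

Going by these compounds, whether the step belongs to the sulfonyl part or to the isopropyl part stays open; a methylsulfonyl or an acetyl group on this nitrogen would separate the two. For the compounds shown here, the effect of the hydroxyl group in compound 1 also has no single-place step of its own.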